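This account rests on a few compounds, and the source may have more. Where it says the series, first, only, none or still open, it means among the compounds named here.

Three measured compounds share one core, and a fourth awaits testing. Compound 1 `O=C(Nc1cccc(-n2cc(-c3ccncc3)c(-c3ccc(Cl)c(O)c3)n2)c1)Nc1ccc(Cl)c(Cl)c1`, compound 2 `COc1cc(-c2nn(-c3cccc(NC(=O)c4cccc(C(F)(F)F)c4)c3)cc2-c2ccncc2)ccc1Cl` and compound 3 `O=C(Nc1cccc(-n2cc(-c3ccncc3)c(-c3ccc(Cl)c(O)c3)n2)c1)Nc1cc(C(F)(F)F)cc(C(F)(F)F)c1` have all been run in a functional assay on MOLT-4 cells (Homo sapiens) for inhibition, read by sulforhodamine B assay, with a stated time of 48 h (on this read-out lower numbers stand for higher toxicity in this test and higher numbers for lower toxicity in this test), and none of them gave a number. In this assay compound 1 reaches only a limit, > 32500 nM. Compound 2 likewise stops at a limit in this assay, > 50000 nM. Compound 3 also ends at a limit, > 50000 nM. So compound 2 stands nowhere in particular among the numbers shown: only a limit is known for it, and the two other values are limits as well, one at the limit of > 32500 nM in this assay, at which 1 of the 3 values shown sits, and two at the limit of > 50000 nM in this assay, at which 2 of the 3 values shown sit.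

Compound 4 `COc1cc(-c2nn(-c3cccc(NC(=O)Nc4ccc(Cl)c(C(F)(F)F)c4)c3)cc2-c2ccncc2)ccc1Cl` differs from compound 2 in one place: (4-chloro-3-(trifluoromethyl)phenyl)amino in place of 3-(trifluoromethyl)phenyl on a carbonyl carbon. The change thus puts an amino group on the carbonyl carbon, as compound 1 and compound 3 already carry. For the step of a number no higher from compound 2 to compound 4 (the limit leaves the size open) no movement beyond the usual scatter is expected, in either direction, since every value shown sits at a limit. Compound 4 is therefore expected to give about 50000 nM in this assay, somewhere between 20000 nM and 120000 nM, most likely again as a limit rather than a number.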

Compound 4, concentration lethal to 50% of the cells: > 32500 nM
Compound 4 ended at the assay's limit; the forecaster's own chance of this, stated with the estimate: 80%; the middle value does not contradict the limit.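

In this assay compound 4 ends at a limit, > 32500 nM. Compound 2 also ends at a limit, > 50000 nM, so the step between compound 2 and compound 4 cannot be read. The compounds shown leave open whether (4-chloro-3-(trifluoromethyl)phenyl)amino in place of 3-(trifluoromethyl)phenyl changes the read-out at all, and at what concentration any of the four compounds would reach it.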